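This account rests on a few compounds, and the source may have more. Where it says the series, first, only, none or still open, it means among the compounds named here.

Among the measured compounds shown here, compound 2 `O=C(O)CCC/C=C1\C[C@H]2C[C@@H](O)[C@H](/C=N/NC(=O)Nc3ccc([N+](=O)[O-])cc3)[C@H]2C1` holds the lowest of the two numbers so far: in a functional assay on a cell-free system (plasma) for agonist activity at thromboxane A2 receptor (Homo sapiens) (on this read-out lower numbers stand for stronger inhibition and higher numbers for weaker inhibition), compound 2 gives 60 nM. Compound 1 `O=C(O)CC/C=C1\C[C@H]2C[C@@H](O)[C@H](/C=N/NC(=O)Nc3cccc(Cl)c3)[C@H]2C1` gives 5200 nM in this assay, a gap beyond the scatter; compound 1 differs from compound 2 in more than one place, so the gap cannot be tied to a single change. Compound 3 `O=C(O)CC/C=C1\C[C@H]2C[C@@H](O)[C@H](/C=N/NC(=O)Nc3ccc([N+](=O)[O-])cc3)[C@H]2C1` is one step from compound 2: carboxy in place of carboxymethyl on a saturated chain carbon, two bonds along the chain from a double-bonded chain carbon. For the measured compounds named here, the carboxy group in place of carboxymethyl is what compound 3 shares with compound 1, whose number in this assay is 5200 nM, the weaker of the pair; that is the only guide available. On that basis the number is expected to rise beyond the scatter a 10-fold higher number from compound 2 to compound 3 (1.00 log units; beyond the scatter), though by less than the whole gap, since compound 1 also carries a different aryl group. For compound 3 the estimate in this assay is 600 nM, with a range from 100 nM to 4000 nM.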

Compound 3, half-maximal inhibitory concentration: 520 nM
Compound 3: middle estimate off by 1.2-fold (0.06 log units), on the high side; the measured number falls inside the stated range.
By their numbers in this assay, from the lowest: compound 2; then compound 3; then compound 1.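

In this assay, carboxy in place of carboxymethyl on a saturated chain carbon, two bonds along the chain from a double-bonded chain carbon, gives an 8.7-fold higher number from compound 2 to compound 3 (0.94 log units; beyond the scatter), so this chain position responds to the change while the 4-nitrophenyl group stays fixed. With the chain held constant, 4-nitrophenyl in place of 3-chlorophenyl on an amide-type nitrogen gives a 10-fold lower number from compound 1 to compound 3 (1.00 log units; beyond the scatter), so the aryl group also matters on its own. No supporting data bear on the reason for either step.

The compounds shown do not tell whether a longer chain carrying the carboxylic acid would lower or raise the number further, or whether an amide could stand in for that acid. A 4-chlorophenyl group would be needed to separate the identity of the aryl substituent from its place on the ring.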